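A few compounds are considered here, and "the series" means these few. Any claim that something is new, unique, unknown or untested is made for them only; others in the source may bear on it.

Measured compounds:
compound 1, `COc1cc2ncnc(N3CCCc4ccccc43)c2cc1NC(=O)/C=C/CN(C)C`, gives 1770 nM in a functional assay on MCF7 cells (Homo sapiens) for antiproliferative activity, read by MTT assay, with a stated time of 72 h; a higher number here means a weaker inhibitor, a lower number a stronger inhibitor.
compound 2, `CCN(CC)C/C=C/C(=O)Nc1cc2c(N3CCCc4ccccc43)ncnc2cc1OC`, gives 5310 nM in this assay.
compound 3, `CN(C)C/C=C/C(=O)Nc1cc2c(N3CCCc4ccccc43)ncnc2cc1O[C@@H]1CCOC1`, gives 2850 nM in this assay.

The three measured compounds share a core and are set apart by two small exchanges. From compound 1 to compound 2 the exchange is diethylamino in place of dimethylamino on a saturated chain carbon bound to a double-bonded chain carbon, and this brought a 3.0-fold higher number from compound 1 to compound 2 (0.48 log units; beyond the scatter), a modest loss of potency that lies beyond the usual scatter. From compound 1 to compound 3 the exchange is oxolan-3-yl in place of methyl on an oxygen on an aromatic ring, and this brought a 1.6-fold higher number from compound 1 to compound 3 (0.21 log units; within the scatter), a difference too small to be read as a real change.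

Compound 4, `CCN(CC)C/C=C/C(=O)Nc1cc2c(N3CCCc4ccccc43)ncnc2cc1O[C@@H]1CCOC1`, has not yet been measured. It carries the same exchange that separates compound 2 from compound 1, now made on the core of compound 3: diethylamino in place of dimethylamino on a saturated chain carbon bound to a double-bonded chain carbon. The place of the exchange is the same in both pairs, so this is the same change made twice, once on each core, and the two cores differ only by the exchange described above from compound 1 to compound 3. Because the earlier occurrence of this change gave a 3.0-fold higher number from compound 1 to compound 2 (0.48 log units; beyond the scatter), the expectation for compound 4 is a step of similar size, a 3.0-fold higher number from compound 3 to compound 4 (0.47 log units; beyond the scatter), a loss of potency relative to compound 3. On that basis compound 4 is estimated to give 8500 nM in this assay, with the likely range estimated to run from 3500 nM to 20000 nM.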

Compound 4, half-maximal inhibitory concentration: 3870 nM
Beside the measured number, compound 4's estimate is 2.2-fold (0.34 log units) above it, within the range that was stated.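

On the core of compound 3, diethylamino in place of dimethylamino gives a 1.4-fold higher number from compound 3 to compound 4 (0.13 log units; within the scatter) in this assay, and this step cannot be told apart from the same change on the core of compound 1: the same change on two cores in this assay, a 3.0-fold higher number (0.48 log units; beyond the scatter) from compound 1 to compound 2 and a 1.4-fold higher number (0.13 log units; within the scatter) from compound 3 to compound 4, 2.2-fold (0.34 log units) apart, within the scatter of two such steps. The other exchange, oxolan-3-yl in place of methyl on an oxygen on an aromatic ring, gives a 1.4-fold lower number from compound 2 to compound 4 (0.14 log units; within the scatter), and it too cannot be told apart from its earlier occurrence: the same change on two cores in this assay, a 1.6-fold higher number (0.21 log units; within the scatter) from compound 1 to compound 3 and a 1.4-fold lower number (0.14 log units; within the scatter) from compound 2 to compound 4, 2.2-fold (0.34 log units) apart, within the scatter of two such steps. Within these four compounds, each change is therefore compatible with carrying over from one core to the other, but this does not show that its effect is the same on both, since the diethylamino step lies beyond the scatter on one core and within it on the other, and two pairs are too few to establish a rule for the series.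

The compounds shown leave open whether the same agreement would hold for other amines on this chain, such as pyrrolidine, piperidine or morpholine, or for a longer chain than methyl on the aromatic oxygen, such as ethyl or propyl. They also leave open whether these small steps would look the same on a third core.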